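Carboxy for acetoxymethyl on the core of compound 1

This account rests on a few compounds, and the source may have more. Where it says the series, first, only, none or still open, it means among the compounds named here.

In a functional assay on HL-60 cells (Homo sapiens) for antiproliferative activity, read by MTT assay, with a stated time of 48 h (on this read-out lower numbers stand for stronger inhibition and higher numbers for weaker inhibition), compound 1 (`CC(=O)OC/C1=C/C[C@](C)(CCC=C(C)C)/C=C/[C@@H](OC(=O)C=C(C)C)[C@](C)(O)/C=C/C1=O`) gives 2950 nM and compound 2 (`CC(=O)OC/C1=C/C[C@](C)(CCC=C(C)C)/C=C/[C@@H](OC(=O)C=C(C)C)[C@](C)(OC(C)=O)/C=C/C1=O`) gives 3480 nM, so a 1.2-fold higher number from compound 1 to compound 2 (0.07 log units; within the scatter) stays within the scatter. Compound 3 (`CO[C@]1(C)/C=C/C(=O)/C(CO)=C\C[C@](C)(CCC=C(C)C)/C=C/[C@H]1OC(=O)C=C(C)C`) gives 14300 nM, a higher number than either, beyond the scatter from compound 1. Compound 4 (`CC(C)=CCC[C@]1(C)/C=C/[C@@H](OC(=O)C=C(C)C)[C@](C)(O)/C=C/C(=O)/C(C(=O)O)=C\C1`) follows from compound 1 by carboxy in place of acetoxymethyl on a double-bonded ring carbon. Among the measured compounds shown here, no measured step touches the acetoxymethyl group, and the one available concerns acetyl on an oxygen, so it offers little guidance. A moderate rise towards the number of compound 3 at 14300 nM is expected, with wide uncertainty. The expected change is a 3.4-fold higher number from compound 1 to compound 4 (0.53 log units; beyond the scatter). Compound 4 is estimated at 10000 nM, within a range of 3000 nM to 35000 nM.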

Compound 4, half-maximal inhibitory concentration: > 10000 nM
Compound 4 was reported as a limit (the forecaster's own chance of this, stated with the estimate: 20%); the middle value sits exactly at the limit.
By their numbers in this assay, from the lowest: compounds 1 and 2 (each within the scatter of the next); then compound 3.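

Among the compounds shown here, the earlier compounds gave no measured step at the acetoxymethyl group, since the only step available concerned acetyl on an oxygen. In this assay, carboxy in place of acetoxymethyl on the double-bonded ring carbon brings an at least 3.3-fold higher number from compound 1 to compound 4 (0.53 log units; beyond the scatter), so this position, unlike that oxygen, responds to a change beyond the scatter. For compound 4 the value > 10000 nM is a limit of the assay, so the size of this step is only a lower bound: the limit of > 10000 nM in this assay, at which 1 of the 4 values shown sits.

As far as these compounds go, how far compound 4 actually lies past this limit remains open. So does whether a methyl ester or a primary amide on this carbon would stay closer to compound 1.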